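Replacing an Oxazole Ring with Phenyl on the Shared Core

The compounds below may be only part of what the source reports. "The series", "measured", "known", "first", "only" and "open" are said of these compounds alone.

Compound 1 `N#Cc1ccc(-c2nc(N)c3cc(Cc4ccccc4)sc3n2)o1` and compound 2 `Nc1nc(-c2ncco2)nc2sc(Cc3ccccc3)cc12` share one core and differ in a single aromatic substituent. In a functional assay on CHO-K1 cells for antagonist activity at adenosine receptor A1 (Homo sapiens), read by a beta-galactosidase reporter and cAMP accumulation, with stated times of 15 min and 6 h (on this read-out lower numbers stand for stronger inhibition and higher numbers for weaker inhibition), compound 1 gives 3160 nM, whereas compound 2 gives 310 nM; the measured step is a 10-fold lower number from compound 1 to compound 2 (1.01 log units; beyond the scatter). Within the data shown here, compound 2 thus holds the lowest of the two numbers so far. Compound 3 `Nc1nc(-c2ccccc2)nc2sc(Cc3ccccc3)cc12` carries phenyl in place of 1,3-oxazol-2-yl on an aromatic carbon. Among the measured compounds shown here, the only measured step concerns a different replacement at the same place and was large, so this place clearly matters, yet nothing shows which way phenyl will move the number. For compound 3 a modest rise is expected, a 1.9-fold higher number from compound 2 to compound 3 (0.29 log units; within the scatter), giving an estimated 600 nM within a range of 150 nM to 2500 nM.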

Compound 3, inhibition constant: 151 nM
Compound 3: middle estimate off by 4.0-fold (0.60 log units), on the high side, and the stated range covers the measured number.
By their numbers in this assay, from the lowest: compound 3; then compound 2; then compound 1.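

Among these compounds, at this place on the shared core, between two ring nitrogen atoms, phenyl gives the lowest number so far (a 2.1-fold lower number from compound 2 to compound 3 (0.31 log units; beyond the scatter)), and the gap to the furan compound is wider still (a 21-fold lower number from compound 1 to compound 3 (1.32 log units; beyond the scatter)). A ring of carbon only, with no hydrogen-bond acceptors, therefore suffices here, so the nitrogen and oxygen of 1,3-oxazol-2-yl are not needed for a low number. No measurement available here explains why the number moves.

Still open, on these data alone, is whether an amine or a carboxylic acid on the phenyl ring would lower the number further or raise it. Also open, as far as these compounds go, is whether a non-aromatic ring such as cyclohexyl could take the place of phenyl.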